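The source may report more compounds than this note shows. Statements on the series, on what has been measured and on what is new or still open speak of the compounds shown alone.

Measured in a functional assay on A549 cells (Homo sapiens) for antiproliferative activity, read by MTT assay, with a stated time of 48 h (on this read-out higher numbers stand for weaker inhibition and lower numbers for stronger inhibition), so far:
- compound 1 `COc1cc(/C=C/c2nnc(NC(=O)c3ccc(Br)cc3)s2)c(Br)c(OC)c1OC`: 160 nM
- compound 2 `COc1cc(/C=C/c2nnc(NC(=O)c3cccc(Cl)c3)s2)c(Br)c(OC)c1OC`: 70 nM

Of these two, compound 2 stands lowest at 70 nM in this assay and so shows the stronger inhibition. The next step leads to compound 3 `COc1cc(/C=C/c2nnc(NC(=O)c3ccccc3)s2)c(Br)c(OC)c1OC`, which has not yet been measured. The change is hydrogen in place of chloro on an aromatic carbon, so that 3-chlorophenyl becomes phenyl. For the measured compounds named here, only one measured step touches this part of the molecule, and it is modest: a 2.3-fold lower number from compound 1 to compound 2 (0.36 log units; beyond the scatter). Going by the values given here, both measured compounds carry a halogen on this ring, so no measured compound shows it without a substituent, and even the direction of the coming step is uncertain. A modest move toward a higher number, similar in size to that one step, is the most likely outcome. The step expected is a 2.1-fold higher number from compound 2 to compound 3 (0.33 log units; beyond the scatter). For compound 3 the estimated value is 150 nM, with an expected range from 50 nM to 450 nM.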

Compound 3, half-maximal inhibitory concentration: 110 nM
Estimate against measurement, compound 3: 1.4-fold (0.13 log units) above; the range from low to high includes it.
By their numbers in this assay, from the lowest: compounds 2, 3 and 1 (each within the scatter of the next, the first and the last beyond it).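

In this assay, for the compounds shown here, compound 3 gives the first reading of this ring with no substituent, and it cannot be separated from either halogen-bearing compound: there is a 1.6-fold higher number from compound 2 to compound 3 (0.20 log units; within the scatter) and a 1.5-fold lower number from compound 1 to compound 3 (0.16 log units; within the scatter). Neither 3-chlorophenyl nor 4-bromophenyl is therefore shown to differ from plain phenyl on this read-out, even though the step between the two halogen-bearing compounds lies beyond the scatter, so replacing either halogen with hydrogen leaves no change that can be read here. No independent measurement is available to explain these numbers.

Going by these compounds, compound 1 and compound 2 differ in both the halogen and its place on the ring, so it remains open whether the halogen itself or its place accounts for the gap between them. Also open, on these data alone, is how this position responds to a group of another kind, such as an amine, a methoxy group or a carboxylic acid, on the aromatic carbon that carries chloro in compound 2.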